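Swapping an aryl group on a weakly active triazole series

The source may report more compounds than this note shows. Statements on the series, on what has been measured and on what is new or still open speak of the compounds shown alone.

Measured so far:
- compound 1, `CCOc1ccccc1-n1nncc1CN1C(=O)C2(C(C#N)=C(N)Oc3c2c2nc4ccccc4nc2c2ccccc32)c2ccccc21`: > 50000 nM in a functional assay on A549 cells (Homo sapiens) for antiproliferative activity, read by MTT assay, with a stated time of 48 h; on this read-out higher numbers stand for weaker inhibition and lower numbers for stronger inhibition
- compound 2, `Cc1ccc(C)c(-n2nncc2CN2C(=O)C3(C(C#N)=C(N)Oc4c3c3nc5ccccc5nc3c3ccccc43)c3ccccc32)c1`: > 50000 nM
- compound 3, `COc1ccccc1-n1nncc1CN1C(=O)C2(C(C#N)=C(N)Oc3c(N)cc4nc5ccccc5nc4c32)c2ccccc21`: 37500 nM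

In this assay compound 1 gives only a limit, > 50000 nM, not a number. Compound 2 likewise gives only a limit, > 50000 nM. Compound 3 is therefore the only one of the three with a true number, 37500 nM, and it stands on the weak side of what the assay can resolve. The step from compound 1 to compound 2 is a step that the two limits leave unreadable from compound 1 to compound 2, so it cannot tell how a change of the aryl group on the triazole nitrogen moves the activity; this follows from the limit of > 50000 nM in this assay, at which 2 of the 3 values shown sit.

Compound 4, `Cc1cc(C)c(-n2nncc2CN2C(=O)C3(C(C#N)=C(N)Oc4c(N)cc5nc6ccccc6nc5c43)c3ccccc32)c(C)c1`, differs from compound 3 by 2,4,6-trimethylphenyl in place of 2-methoxyphenyl on an aromatic nitrogen. For the measured compounds named here, the only comparable change, from compound 1 to compound 2, left no readable step, so no direction can be drawn from it. For compound 4 the step from compound 3 is expected to be a 1.2-fold higher number from compound 3 to compound 4 (0.08 log units; within the scatter), that is, no change beyond the scatter. Compound 4 is therefore estimated at 45000 nM, within 25000 nM to 80000 nM, with a real chance that this assay again reports only a limit.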

Compound 4, half-maximal inhibitory concentration: 12700 nM
For compound 4 the middle estimate is 3.5-fold (0.55 log units) above the measured one; measured number below the stated range.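

In this assay, the aryl group on the aromatic nitrogen of the five-membered aromatic ring with 3 nitrogen now gives a readable result: 2,4,6-trimethylphenyl in place of 2-methoxyphenyl gives a 3.0-fold lower number from compound 3 to compound 4 (0.47 log units; beyond the scatter). This shows that the activity of the series does respond to the choice of aryl group at this position, which the earlier aryl swap could not show, because that step cannot be read: the limit of > 50000 nM in this assay, at which 2 of the 4 values shown sit. The change replaces a group containing oxygen with one of carbon only, but no measured property of either group is available to account for the step.

A single pair cannot separate the effect of adding the methyl groups from that of removing the methoxy group, and a plain phenyl or a 2-methylphenyl group at this place would begin to pull the two apart. Going by these compounds, it also remains open whether 2,4,6-trimethylphenyl would behave the same way on the core of compound 1, and how an aryl ring carrying an amine or a carboxylic acid would fare here.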